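Compound 1 to compound 4: replacing the 3-chlorophenyl group

The source may report more compounds than this note shows. Statements on the series, on what has been measured and on what is new or still open speak of the compounds shown alone.

In a functional assay on HL-60 cells (Homo sapiens) for inhibition, read by MTT assay, with a stated time of 72 h (a higher number here means a weaker inhibitor, a lower number a stronger inhibitor), compound 1 `Cc1nc(-c2ccccc2)c(C(=O)N2CCN(c3cccc(Cl)c3)CC2)o1` gives 39.2 nM, level with compound 2 `Cc1nc(-c2ccc(F)cc2)c(C(=O)N2CCN(c3cccc(Cl)c3)CC2)o1` at 40.1 nM, a 1.0-fold higher number from compound 1 to compound 2 (0.01 log units; within the scatter). Compound 3 `CC(=O)Nc1cccc(-c2nc(C)oc2C(=O)N2CCN(c3cccc(Cl)c3)CC2)c1` gives 208 nM, a 5.3-fold higher number from compound 1 to compound 3 (0.72 log units; beyond the scatter), and compound 1 therefore sits at the low end of the numbers.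

Compound 4 `C=C(C)c1ccc(N2CCN(C(=O)c3oc(C)nc3-c3ccccc3)CC2)cc1` carries 4-(1-methylethenyl)phenyl in place of 3-chlorophenyl on an amine nitrogen in a ring. Among the compounds with values here, no measured step touches this place, since compound 1, compound 2 and compound 3 all carry 3-chlorophenyl there. The step to compound 3, a 5.3-fold higher number from compound 1 to compound 3 (0.72 log units; beyond the scatter), is only a rough guide to size, so a modest rise is expected, with wide uncertainty.

The expected step is a 1.5-fold higher number from compound 1 to compound 4 (0.18 log units; within the scatter). For compound 4 the estimate is 60 nM, with an expected range of 15 nM to 240 nM.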

Compound 4, half-maximal inhibitory concentration: "not active" (no number reported)
Compound 4 has no reported number here, and the estimate cannot be compared.
By their numbers in this assay, from the lowest: compounds 1 and 2 (each within the scatter of the next); then compound 3.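

Within the data shown here, compound 4 is reported as not active in this assay with no number, so no step from compound 1 to compound 4 can be read. No evidence shown bears on this result. The compounds shown leave open how any other group in place of 3-chlorophenyl on the ring amine nitrogen would read in this assay.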